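Aryl swap on the carbonyl in a trimethoxyphenyl-pyrazole chalcone series

This account rests on a few compounds, and the source may have more. Where it says the series, first, only, none or still open, it means among the compounds named here.

The series shares one core, shown by compound 1 `COc1cc(-c2cc(/C=C/C(=O)c3ccc(N)cc3)[nH]n2)cc(OC)c1OC`, which carries a 4-aminophenyl on the carbonyl carbon. In a functional assay on IGROV-1 cells (Homo sapiens) for cytotoxicity, read by sulforhodamine B assay, with a stated time of 48 h, tested at 1 uM (a higher number here means a weaker effect of the compound at the concentration tested, a lower number a stronger effect), compound 1 gives 100%. Compound 2 `COc1cc(-c2cc(/C=C/C(=O)c3ccc(Cl)c(Cl)c3)[nH]n2)cc(OC)c1OC` carries a 3,4-dichlorophenyl in the same place, and in this assay compound 2 gives 99%. For the measured compounds named here, the only measured step, a number 1 percentage points lower from compound 1 to compound 2 (within the scatter), lies within the scatter, so compound 2 and compound 1 stand together at the top of the scale, and neither can be called weaker or stronger than the other.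

Compound 3 `COc1ccc(C(=O)/C=C/c2cc(-c3cc(OC)c(OC)c(OC)c3)n[nH]2)cc1OC` is not yet measured. The change from compound 2 is 3,4-dimethoxyphenyl in place of 3,4-dichlorophenyl on a carbonyl carbon. Going by the values given here, the one step that bears on it, a number 1 percentage points lower from compound 1 to compound 2 (within the scatter), shows that exchanging the aryl group on the carbonyl carbon left the read-out unmoved; with both measured numbers at the ceiling, no step beyond the scatter is expected for this assay either. Compound 3 is therefore estimated at 97%, with a range of 84% to 102%, a step of a number 2 percentage points lower from compound 2 to compound 3 (within the scatter) that is expected to stay within the scatter.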

Compound 3, a percentage reported as activity, at one concentration (the size of the read-out at that concentration, not a potency): 96%
Estimate against measurement, compound 3: 1 percentage points above, within the range that was stated.
By their numbers in this assay, from the lowest: compounds 3, 2 and 1 (each within the scatter of the next).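

In this assay, the exchange at this place gives a number 3 percentage points lower from compound 2 to compound 3 (within the scatter) and, measured against the 4-aminophenyl compound, a number 4 percentage points lower from compound 1 to compound 3 (within the scatter), so all three aryl groups tested on the carbonyl carbon now sit within the scatter of each other. What compound 3 adds is a different kind of substituent: 3,4-dimethoxyphenyl brings 10 heavy atoms and 2 hydrogen-bond acceptors, where 3,4-dichlorophenyl has 8 heavy atoms and 0 hydrogen-bond acceptors, and even this change in atom types and counts yields no step beyond the scatter at the single concentration tested. No measurement at hand accounts for this flat read-out.

With every number near the top of the scale, the compounds shown do not establish whether any group on the carbonyl carbon can move this read-out beyond the scatter. Going by these compounds, a carboxylic acid on the aryl ring, or a longer chain in place of the aryl group, remains open, as does any change to the shared core outside this place.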